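Three limits and a trifluoromethyl exchange

The source may hold more compounds than are shown below. What is called first, only, known or untested is meant among the compounds shown, and "the series" means these compounds.

Measured in an ADME assay on HeLa cells (Homo sapiens) for cytotoxicity, read by MTT assay; a lower number here means a stronger inhibitor, a higher number a weaker inhibitor (each value is a limit of the assay, not a number):
Compound 1 `N#Cc1c(-c2cccc(F)c2)c(C#N)c(=O)n(/N=C/c2cn(-c3ccccc3)nc2-c2ccccc2)c1N` gives > 200 ug/mL as a limit
Compound 2 `N#Cc1c(-c2ccc(F)cc2)c(C#N)c(=O)n(/N=C/c2cn(-c3ccccc3)nc2-c2ccccc2)c1N` gives > 200 ug/mL as a limit
Compound 3 `COc1cc(-c2c(C#N)c(N)n(/N=C/c3cn(-c4ccccc4)nc3-c3ccccc3)c(=O)c2C#N)cc(OC)c1OC` gives > 200 ug/mL as a limit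

Compound 3 is known only through the limit > 200 ug/mL and has no number. The whole set sits at the same place (the limit of > 200 ug/mL in this assay, at which 3 of the 3 values shown sit). Compound 4 `N#Cc1c(-c2ccc(C(F)(F)F)cc2)c(C#N)c(=O)n(/N=C/c2cn(-c3ccccc3)nc2-c2ccccc2)c1N` carries 4-(trifluoromethyl)phenyl in place of the 3,4,5-trimethoxyphenyl of compound 3, on an aromatic carbon opposite the ring nitrogen (4-(trifluoromethyl)phenyl in place of 3,4,5-trimethoxyphenyl on an aromatic carbon).

Three measured steps, all exchanges on that same carbon, bear on this change: (a step that the two limits leave unreadable from compound 1 to compound 2), (a step that the two limits leave unreadable from compound 1 to compound 3) and (a step that the two limits leave unreadable from compound 2 to compound 3). None has a readable size, so they set no size or direction for the new step. In this assay compound 4 is expected to reach the same limit, with no shift beyond the scatter. The expected step is (a step that the limit leaves unreadable from compound 3 to compound 4). For compound 4 the estimated value is 250 ug/mL with an expected range from 100 ug/mL to 500 ug/mL in this estimate.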

Compound 4, half-maximal inhibitory concentration: > 200 ug/mL
Compound 4 was reported as a limit; the forecaster's own chance of this, stated with the estimate: 85%; the middle value is on the limit's open side.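

In this assay compound 4 gives > 200 ug/mL as a limit and not a number. For the compounds shown here, no step from compound 1, compound 2 or compound 3 to compound 4 can be read: all four values are limits. The compounds shown leave open how far, and in which direction, any of these exchanges on the aromatic carbon would move the value.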